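This account rests on a few compounds, and the source may have more. Where it says the series, first, only, none or still open, it means among the compounds named here.

Working notes on the series. The common core appears in compound 1 `CCN1CCN(C[C@H]2CN(c3ccc(-n4cc(-c5ccccn5)cn4)c(F)c3)C(=O)O2)CC1`, compound 2 `O=C1O[C@@H](CN2CCC(c3ccc(F)cc3)CC2)CN1c1ccc(-n2cc(-c3ccccn3)cn2)c(F)c1` and compound 3 `COC[C@H]1CN(c2ccc(-n3cc(-c4ccccn4)cn3)c(F)c2)C(=O)O1`, which differ only at the saturated chain carbon bound to a saturated ring carbon. In an ADME assay on HEK293-A cells (Homo sapiens) for cytotoxicity, read by MTT assay, with a stated time of 48 h (a lower number here means a stronger inhibitor, a higher number a weaker inhibitor), compound 1 gives 99 ug/mL. Compound 2 reaches only a limit of this assay, > 400 ug/mL. Compound 3 also reaches only a limit, > 400 ug/mL. Two of the three values shown therefore sit at the limit of > 400 ug/mL in this assay, at which 2 of the 3 values shown sit, and compound 3 stands at that limit rather than at a number. For the measured compounds named here, the one measured step, an at least 4.0-fold higher number from compound 1 to compound 3 (0.60 log units; beyond the scatter), moves toward weaker cytotoxicity and ends at the limit, so its full size is not known.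

Compound 4 `O=C(NC[C@H]1CN(c2ccc(-n3cc(-c4ccccn4)cn3)c(F)c2)C(=O)O1)C(F)F` differs from compound 3 by ((difluoromethyl)carbonyl)amino in place of methoxy on a saturated chain carbon bound to a saturated ring carbon. Going by the values given here, no measured step covers this exchange; the step from compound 1 to compound 3 concerns a different group leaving the same position. With both neighbours of the change at the limit, the step of an at least 1.1-fold lower number from compound 3 to compound 4 (0.05 log units; that floor lies within the scatter) is expected to stay within the scatter. Compound 4 is therefore estimated at 350 ug/mL, with a range from 150 ug/mL to 400 ug/mL.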

Compound 4, half-maximal inhibitory concentration: 167 ug/mL
Beside the measured number, compound 4's estimate is 2.1-fold (0.32 log units) above it; measured number inside the range.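

On a saturated chain carbon bound to a saturated ring carbon, the move away from the limit no longer depends on 4-ethylpiperazin-1-yl: in this assay, ((difluoromethyl)carbonyl)amino in place of methoxy gives an at least 2.3-fold lower number from compound 3 to compound 4 (0.37 log units; beyond the scatter). This open-chain group with no net charge and 4-ethylpiperazin-1-yl are not separated in this assay, which shows a 1.7-fold higher number from compound 1 to compound 4 (0.23 log units; within the scatter). The exchange from methoxy has only a floor for its size, because compound 3 stands at a limit: the limit of > 400 ug/mL in this assay, at which 2 of the 4 values shown sit.

As far as these compounds go, whether the step depends on the two fluorines or on the amide itself stays open; an acetylamino group or a free primary amine on the same carbon would address that. From the compounds shown here alone, how far compound 2 and compound 3 lie beyond their limits also stays open.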